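Swapping a ring-bearing chain for a short branched one

The source may hold more compounds than are shown below. What is called first, only, known or untested is meant among the compounds shown, and "the series" means these compounds.

Compounds measured so far:
- compound 1 `CNC(=O)c1cc(C(=O)NC2CC2)cn(Cc2cccc(OC)c2)c1=O` gives 3 in a physicochemical assay for lipophilicity, at pH 7.4; on this read-out higher numbers stand for higher lipophilicity and lower numbers for lower lipophilicity
- compound 2 `CNC(=O)c1cc(C(=O)NCCC2CCOCC2)cn(Cc2ccccc2)c1=O` gives 3.6 in this assay
- compound 3 `CNC(=O)c1cc(C(=O)NC2CC2)cn(Cc2cccc3cc[nH]c23)c1=O` gives 3.7 in this assay

Compound 2 stands second highest of the three numbers: compound 3 sits closest to it, within the scatter, while compound 1 lies furthest, beyond the scatter. Among the measured compounds shown here, the only step measured between two compounds that differ in one place is a number 0.70 log units higher from compound 1 to compound 3 (beyond the scatter), which concerns the group on the chain carbon bound to the aromatic nitrogen.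

Compound 4 `CNC(=O)c1cc(C(=O)NCC(C)C)cn(Cc2ccccc2)c1=O` differs from compound 2 at a different place: isopropyl in place of (oxan-4-yl)methyl on a saturated chain carbon bound to an amide-type nitrogen. For the measured compounds named here, no measured step touches this position, so nothing directly anchors the expectation. The group that leaves carries one hydrogen-bond acceptor and a ring; the group that enters carries neither but is also much smaller. These two effects pull in opposite directions, and a step from compound 2 to compound 4 of a number 0.10 log units higher from compound 2 to compound 4 (within the scatter) is expected, that is, close to no change beyond the scatter. For compound 4 a value of 3.7 is estimated, between 3.2 and 4.2.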

Compound 4, distribution coefficient: 4.3
Beside the measured number, compound 4's estimate is 0.60 log units below it; measured number above the stated range.
By their numbers in this assay, from the lowest: compound 1; then compounds 2 and 3 (each within the scatter of the next); then compound 4.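

Among the compounds shown here, this is the first measured step at the place on a saturated chain carbon bound to an amide-type nitrogen, and it shows that the group there matters in this assay. Isopropyl in place of (oxan-4-yl)methyl gives a number 0.70 log units higher from compound 2 to compound 4 (beyond the scatter) and so the group with no ring and no hydrogen-bond acceptor carries the higher number in this pair. No measurement at hand gives a reason for this step.

The step changes the ring, its oxygen and the heavy-atom count all at once, so the compounds shown cannot separate these differences. Cyclohexylmethyl would keep a ring without the oxygen, while a longer unbranched chain such as n-hexyl would have neither, and their values remain open.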